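Cutting the acetyl group from compound 3

The compounds below may be only part of what the source reports. "The series", "measured", "known", "first", "only" and "open" are said of these compounds alone.

In a functional assay on DU-145 cells (Homo sapiens) for inhibition, read by trypan blue exclusion, with a stated time of 96 h (on this read-out higher numbers stand for weaker inhibition of growth and lower numbers for stronger inhibition of growth), compound 1 `O=C(O)c1ccc(C(=O)/C(=C\c2ccc(Br)cc2)SCc2ccc(F)cc2)cc1` gives > 100000 nM, which is a limit of the assay. Compound 2 `O=C(O)c1ccc(C(=O)/C(=C\c2ccc(F)c([N+](=O)[O-])c2)SCc2ccc(F)cc2)cc1` gives 1000 nM, and compound 3 `CC(=O)Nc1ccc(/C=C(/SCc2ccc(F)cc2)C(=O)c2ccc(C(=O)O)cc2)cc1[N+](=O)[O-]` gives 10000 nM, the higher of the two exact numbers. Compound 4 `Nc1ccc(/C=C(/SCc2ccc(F)cc2)C(=O)c2ccc(C(=O)O)cc2)cc1[N+](=O)[O-]` has hydrogen in place of acetyl on a nitrogen on an aromatic ring, turning acetamido into amino. The closest guide is the modest 10-fold higher number from compound 2 to compound 3 (1.00 log units; beyond the scatter), which introduced the acetamido group. The large at least 100-fold lower number from compound 1 to compound 2 (2.00 log units; beyond the scatter) involves a different change and bears on it only loosely. A modest move to a lower number is therefore expected, estimated as a 3.3-fold lower number from compound 3 to compound 4 (0.52 log units; beyond the scatter). Compound 4 is estimated at 3000 nM, with an expected range of 600 nM to 15000 nM.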

Compound 4, concentration for 50% growth inhibition: 10000 nM
For compound 4 the middle estimate is 3.3-fold (0.52 log units) below the measured one, and the stated range covers the measured number.
By their numbers in this assay, from the lowest: compound 2; then compounds 3 and 4 (each within the scatter of the next). At a limit, above all of these: compound 1.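

Removing the acetyl group from the nitrogen on the aromatic ring leaves the growth inhibition in this assay unchanged (no change at the digits printed from compound 3 to compound 4 (within the scatter)), so acetamido and amino cannot be told apart at this position. Compared with fluoro, amino gives the same result as acetamido (a 10-fold higher number from compound 2 to compound 4 (1.00 log units; beyond the scatter)), and compound 2 stays apart from both compound 3 and compound 4. Compound 1 stands at a limit, and its step reads (an at least 10-fold lower number from compound 1 to compound 4 (1.00 log units; beyond the scatter)): the limit of > 100000 nM in this assay, at which 1 of the 4 values shown sits.

On these data alone, whether a methoxy or dimethylamino group on that aromatic carbon would read like fluoro or like amino remains open.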